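Swapping the urea aryl group on a methoxy-bearing core

The source may hold more compounds than are shown below. What is called first, only, known or untested is meant among the compounds shown, and "the series" means these compounds.

Three urea compounds have been measured in an assay on isolated protein for inhibition of serine/threonine-protein kinase PLK1 (Homo sapiens), read by radiometric assay and 33P incorporation, with a stated time of 40 min, tested at 20 uM, in the presence of a further agent that is not named here; on this read-out higher numbers stand for more inhibition at the one concentration tested (going by the name of the read-out) and lower numbers for less inhibition. Compound 1 `CCNc1cc(-c2ccc(NC(=O)Nc3c(C)cccc3C)cc2C(F)(F)F)ccn1` gives 59.2%, compound 2 `CCNc1cc(-c2ccc(NC(=O)Nc3ccccc3Cl)cc2C(F)(F)F)ccn1` gives 71.6%, and compound 3 `CCNc1cc(-c2ccc(NC(=O)Nc3c(C)cccc3C)cc2OC)ccn1` gives 54.4%.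

The change from compound 1 to compound 2 is 2-chlorophenyl in place of 2,6-dimethylphenyl on an amide-type nitrogen. This brought a number 12.4 percentage points higher from compound 1 to compound 2 (beyond the scatter). The two cores differ as described by methoxy in place of trifluoromethyl on an aromatic carbon, and on this change the result was a number 4.8 percentage points lower from compound 1 to compound 3 (within the scatter), so compound 1 and compound 3 cannot be told apart by this read-out.

Compound 4 `CCNc1cc(-c2ccc(NC(=O)Nc3ccccc3Cl)cc2OC)ccn1` has not yet been measured. It differs from compound 3 by 2-chlorophenyl in place of 2,6-dimethylphenyl on an amide-type nitrogen, the same change that separates compound 1 from compound 2, this time made on the core of compound 3. Since the core change itself left the read-out unchanged, the step is expected to look like the earlier one, a number 11.6 percentage points higher from compound 3 to compound 4 (beyond the scatter) set beside a number 12.4 percentage points higher from compound 1 to compound 2 (beyond the scatter), resting on compound 1 and compound 2 alone. The value of compound 4 is therefore estimated at 66%, with a likely range from 52% to 78%.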

Compound 4, a percentage reported as inhibition, at one concentration (the size of the read-out at that concentration, not a potency): 53.6%
Compound 4: middle estimate off by 12.4 percentage points, on the high side; the range from low to high includes it.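

In this assay, 2-chlorophenyl in place of 2,6-dimethylphenyl on the core of compound 3 gave a number 0.8 percentage points lower from compound 3 to compound 4 (within the scatter), and set against the earlier step on the core of compound 1, the two cannot be told apart: the same change on two cores in this assay, a number 12.4 percentage points higher (beyond the scatter) from compound 1 to compound 2 and a number 0.8 percentage points lower (within the scatter) from compound 3 to compound 4, 13.2 percentage points apart, within the scatter of two such steps

Read the other way, methoxy in place of trifluoromethyl with 2-chlorophenyl on the urea gave a number 18 percentage points lower from compound 2 to compound 4 (beyond the scatter), and this step also cannot be separated from its earlier counterpart: the same change on two cores in this assay, a number 4.8 percentage points lower (within the scatter) from compound 1 to compound 3 and a number 18 percentage points lower (beyond the scatter) from compound 2 to compound 4, 13.2 percentage points apart, within the scatter of two such steps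

The four compounds therefore do not show that the rise seen on the core of compound 1 carries over to the methoxy-bearing core, and they do not show that the two cores respond differently either.

As far as these compounds go, it remains open whether another group on the urea, such as a plain phenyl, would separate the two cores more clearly, or whether a nitrile in place of methoxy would change the picture. Since each number comes from a single concentration, the potency of these compounds also remains open.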